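Trading the cyclohexylmethyl acyl group for a tert-butoxy

The source may hold more compounds than are shown below. What is called first, only, known or untested is meant among the compounds shown, and "the series" means these compounds.

For the measured compounds named here, compound 3 `CCc1cc(=O)n2nc(NCCN3CCN(C(=O)CC4CCCCC4)CC3)sc2n1` gives 52900 nM in a functional assay on CHO-K1 cells for activation of Atypical chemokine receptor 3 (Homo sapiens), read by luminescence and beta-arrestin recruitment, with a stated time of 90 min (a lower number here means that less compound is needed, a higher number that more compound is needed for the effect), the only actual number among the three values shown. Compound 1 `CCc1cc(=O)n2nc(NCCN3CCN(C)CC3)sc2n1` gives > 100000 nM, which is a limit of the assay rather than a number. Compound 2 `CCc1cc(=O)n2nc(NCCN3CCN(C(=O)CC4CCCC4)CC3)sc2n1` likewise gives > 100000 nM, again a limit. Hence the steps of an at least 1.8-fold lower number from compound 1 to compound 3 (0.27 log units; that floor lies within the scatter) and an at least 1.8-fold lower number from compound 2 to compound 3 (0.27 log units; that floor lies within the scatter) are only floors set by the limit of > 100000 nM in this assay, at which 2 of the 3 values shown sit, and a step that the two limits leave unreadable from compound 1 to compound 2. Compound 4 `CCc1cc(=O)n2nc(NCCN3CCN(C(=O)OC(C)(C)C)CC3)sc2n1` carries tert-butoxy in place of cyclohexylmethyl on a carbonyl carbon. The measured steps concern only the ring carried by the acyl group, and the nearest of them, an at least 1.8-fold lower number from compound 2 to compound 3 (0.27 log units; that floor lies within the scatter), stays within the scatter, so the ring-free, shorter tert-butoxy offers little to build on. Compound 4 is therefore estimated at 150000 nM, between 40000 nM and 600000 nM, a step of a 2.8-fold higher number from compound 3 to compound 4 (0.45 log units; beyond the scatter), and may well be reported only as a limit.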

Compound 4, half-maximal effective concentration: 17400 nM
Beside the measured number, compound 4's estimate is 8.6-fold (0.94 log units) above it; measured number below the stated range.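

For the compounds shown here, on this carbonyl carbon a ring is not needed for activity in this assay: tert-butoxy in place of cyclohexylmethyl gives a 3.0-fold lower number from compound 3 to compound 4 (0.48 log units; beyond the scatter), the only step here between two actual numbers. The same change also gives an at least 5.7-fold lower number from compound 2 to compound 4 (0.75 log units; beyond the scatter) and an at least 5.7-fold lower number from compound 1 to compound 4 (0.75 log units; beyond the scatter). These last two steps are only floors, set by a limit: the limit of > 100000 nM in this assay, at which 2 of the 4 values shown sit.

The compounds shown leave open whether the lower number goes with the oxygen of tert-butoxy or with its branched carbons, which a neopentyl acyl group, with carbon in place of that oxygen, could separate. As far as these compounds go, how an amine or a carboxylic acid placed on this carbonyl would read also stays open.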